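The source may report more compounds than this note shows. Statements on the series, on what has been measured and on what is new or still open speak of the compounds shown alone.

Working notes on the series. Among the measured compounds shown here, in a functional assay on SW480 cells (Homo sapiens) for antiproliferative activity, read by MTT assay, with a stated time of 48 h (on this read-out lower numbers stand for stronger inhibition and higher numbers for weaker inhibition), compound 1 (`CCCCCCCC(CCO)n1cnc2c(NC)ncnc21`) gives 15300 nM, the only true number among the three compounds measured so far. Compound 2 (`CCCCCCCC(CCO)n1cnc2c(N(C)C)ncnc21`) returns only a limit, > 50000 nM. Compound 3 (`CCCCCCCC(CCO)n1cnc2c(N)ncnc21`) also returns only a limit, > 50000 nM. Readings in this set are therefore bounded by the limit of > 50000 nM in this assay, at which 2 of the 3 values shown sit.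

Compound 4 (`CCCCCCCCCCCC(CCO)n1cnc2c(NC)ncnc21`) keeps the core of compound 1 and changes only the chain: butyl in place of hydrogen on a saturated chain carbon, eight bonds along the chain from an aromatic nitrogen.

The measured steps all concern the substituent on the aromatic carbon or its nitrogen, not the chain. They are an at least 3.2-fold higher number from compound 1 to compound 2 (0.51 log units; beyond the scatter), an at least 3.2-fold higher number from compound 1 to compound 3 (0.51 log units; beyond the scatter) and a step that the two limits leave unreadable from compound 2 to compound 3. Both readable steps run upward from compound 1, but neither sizes a chain change, so they bear on this step only indirectly. They do show that compound 1 carries the one substitution pattern here that gives a number, and compound 4 retains it.

The starting point is thus compound 1 at 15300 nM in this assay, with a modest move to a lower number expected and a wide margin either way. For compound 4 the expected value is 7000 nM. The estimated range for compound 4 runs from 2000 nM to 30000 nM. The estimate amounts to a 2.2-fold lower number from compound 1 to compound 4 (0.34 log units; beyond the scatter).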

Compound 4, half-maximal inhibitory concentration: 12800 nM
For compound 4 the middle estimate is 1.8-fold (0.26 log units) below the measured one; the measured number falls inside the stated range.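

In this assay, butyl in place of hydrogen on this saturated chain carbon, eight bonds along the chain from an aromatic nitrogen, gives a 1.2-fold lower number from compound 1 to compound 4 (0.08 log units; within the scatter), so compound 1 and compound 4 read alike. Among the compounds shown here, the earlier compounds varied only the substituent on the aromatic carbon or its nitrogen, so this is the first reading of the chain, and at this position the added butyl is tolerated with the methylamino pattern kept. Compound 4 returns a true number rather than a limit, so the chain change can be sized on this scale at all: the limit of > 50000 nM in this assay, at which 2 of the 4 values shown sit.

As far as these compounds go, whether a chain longer than that of compound 4, or an amine or a carboxylic acid carried on the chain at this position, would separate from compound 1 beyond the scatter stays open. Also open, from the compounds shown here alone, is whether the same butyl on compound 2 or compound 3, each of which gives only a limit, would yield a true number.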